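Aryl variation at the biaryl position: cytotoxicity notes

This account rests on a few compounds, and the source may have more. Where it says the series, first, only, none or still open, it means among the compounds named here.

Measured compounds:
compound 1 `Cc1cc(-c2ccccc2C(F)(F)F)cc(C)c1Nc1ccnc(Nc2ccc(C#N)cc2)n1` — 4210 nM
compound 2 `Cc1cc(C)cc(-c2cc(C)c(Nc3ccnc(Nc4ccc(C#N)cc4)n3)c(C)c2)c1` — 4140 nM
compound 3 `Cc1ccc(-c2cc(C)c(Nc3ccnc(Nc4ccc(C#N)cc4)n3)c(C)c2)cc1` — 5570 nM

In an ADME assay on MT4 cells (Homo sapiens) for cytotoxicity, read by MTT assay, with a stated time of 4 days (on this read-out lower numbers stand for higher toxicity in this test and higher numbers for lower toxicity in this test), the three measured compounds give numbers that all fall within the usual scatter of one another. Compound 3 carries the 4-methylphenyl group and, compared with the others, shows a 1.3-fold higher number from compound 1 to compound 3 (0.12 log units; within the scatter) and a 1.3-fold higher number from compound 2 to compound 3 (0.13 log units; within the scatter); neither step is beyond the scatter. Likewise a 1.0-fold lower number from compound 1 to compound 2 (0.01 log units; within the scatter) shows no movement when 2-(trifluoromethyl)phenyl gives way to 3,5-dimethylphenyl. On these numbers the aryl group on the shared core has not shifted the read-out in this assay.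

Compound 4 `COc1cccc(-c2cc(C)c(Nc3ccnc(Nc4ccc(C#N)cc4)n3)c(C)c2)c1` is not yet measured. It differs from compound 3 by 3-methoxyphenyl in place of 4-methylphenyl on an aromatic carbon. The three steps already seen, each swapping one aryl group for another at the same aromatic carbon, bear on this change, and all lay within the scatter. The expected step of a 1.1-fold lower number from compound 3 to compound 4 (0.05 log units; within the scatter) is therefore none beyond the scatter. The estimated value for compound 4 in this assay is 5000 nM, with a range from 2500 nM to 10000 nM.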

Compound 4, half-maximal cytotoxic concentration: 2990 nM
For compound 4 the middle estimate is 1.7-fold (0.22 log units) above the measured one, and the stated range covers the measured number.
By their numbers in this assay, from the lowest: compounds 4, 2, 1 and 3 (each within the scatter of the next).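

In this assay the 3-methoxyphenyl group, which brings an oxygen atom to this aromatic carbon, gives a 1.9-fold lower number from compound 3 to compound 4 (0.27 log units; within the scatter) and a 1.4-fold lower number from compound 2 to compound 4 (0.14 log units; within the scatter) and also a 1.4-fold lower number from compound 1 to compound 4 (0.15 log units; within the scatter) against the three earlier aryl groups. Among these compounds, the first of these steps is the largest seen so far, yet it stays within the scatter, so the flat picture from the earlier compounds now also covers an aryl group with a hydrogen-bond acceptor, for these four compounds only. Nothing at hand accounts for how closely these numbers sit together.

Still open, as far as these compounds go, is whether an amine or a carboxylic acid on this aryl group, or a longer alkoxy chain in place of methoxy, would stay within the scatter. Also open, from the compounds shown here alone, is whether a saturated ring such as morpholine could replace the aryl group at this position with the same result.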